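A few compounds are considered here, and "the series" means these few. Any claim that something is new, unique, unknown or untested is made for them only; others in the source may bear on it.

Measured so far:
- compound 1 `CNC(=O)c1cc(Oc2ccc(/C=C/C(=O)c3ccc(C)cc3)cc2)ccn1`: "not determined" (no result reported)
- compound 2 `CNC(=O)c1cc(Oc2ccc(C(=O)/C=C/c3ccccc3)cc2)ccn1`: 5040 nM
- compound 3 `CNC(=O)c1cc(Oc2ccc(C(=O)/C=C/c3ccc(Br)cc3)cc2)ccn1`: > 50000 nM

In a functional assay on A549 cells (Homo sapiens) for cytotoxicity, read by MTT assay, with a stated time of 72 h (on this read-out higher numbers stand for weaker inhibition and lower numbers for stronger inhibition), compound 1 stands without a result, as "not determined" (no result reported) says. Compound 2 gives 5040 nM in this assay. For compound 3 the assay reports only a limit, > 50000 nM, not a number. For the measured compounds named here, the one step measured, an at least 9.9-fold higher number from compound 2 to compound 3 (0.99 log units; beyond the scatter), is the only guide; it rests on a limit, since the limit of > 50000 nM in this assay, at which 1 of the 3 values shown sits, applies.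

Compound 4 `CNC(=O)c1cc(Oc2ccc(/C=C/C(=O)c3ccc(Br)cc3)cc2)ccn1` differs from compound 1 in one place: bromo in place of methyl on an aromatic carbon. Going by the values given here, no measured step matches this change, and compound 1 itself has no number to start from. The closest evidence is the step from compound 2 to compound 3, where bromo entering an aromatic carbon moved the number to the limit. On that basis the number for compound 4 in this assay is expected to be high, likely near the upper end of what the assay resolves, with a considerable chance that only a limit is reported. Compound 4 is therefore estimated at 30000 nM, within 6000 nM to 50000 nM.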

Compound 4, half-maximal inhibitory concentration: 20100 nM
Estimate against measurement, compound 4: 1.5-fold (0.17 log units) above; the range from low to high includes it.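

In this assay, for the compounds shown here, compound 4 gives 20100 nM, while compound 1 stands at "not determined" (no result reported), so no step between compound 1 and compound 4 can be read. The compounds shown leave open how 4-methylphenyl and 4-bromophenyl compare on the shared core in this assay.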